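The source may hold more compounds than are shown below. What is called first, only, known or untested is meant among the compounds shown, and "the series" means these compounds.

These notes follow the series in a functional assay on K562 cells (Homo sapiens) for antiproliferative activity, read by MTT assay, with a stated time of 24 h (on this read-out lower numbers stand for stronger inhibition and higher numbers for weaker inhibition), through its three measured members. Compound 3 `COc1ccccc1/C=C/C(=O)c1ccc(OC)c2c1OC(C)(C)C=C2` gives > 10000 nM as a limit of the assay and not as a number. Compound 1 `COc1cccc(/C=C/C(=O)c2ccc(OC)c3c2OC(C)(C)C=C3)c1` gives > 10000 nM as a limit too. Compound 2 `COc1ccc(C(=O)/C=C/c2ccccc2Cl)c2c1C=CC(C)(C)O2` gives > 10000 nM as a limit as well. Compound 3 therefore has no measured rank in this set, and the three together show the limit of > 10000 nM in this assay, at which 3 of the 3 values shown sit, and nothing finer.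

The next member is compound 4 `COc1ccc(C(=O)/C=C/c2cc(Cl)ccc2O)c2c1C=CC(C)(C)O2` and the change is 5-chloro-2-hydroxyphenyl in place of 2-methoxyphenyl on a double-bonded chain carbon bound to a double-bonded chain carbon in one place: 5-chloro-2-hydroxyphenyl in place of 2-methoxyphenyl on a double-bonded chain carbon bound to a double-bonded chain carbon. Among the compounds with values here, the steps that bear on this place are a step that the two limits leave unreadable from compound 1 to compound 2 and a step that the two limits leave unreadable from compound 1 to compound 3 and a step that the two limits leave unreadable from compound 2 to compound 3 and none of them has a readable size. None of compound 1, compound 2 or compound 3 carries the entering group.

With compound 3 at > 10000 nM as a limit, no definite step is expected in this assay and any expected shift runs toward stronger inhibition. The estimated change is a number no higher from compound 3 to compound 4 (the limit leaves the size open) and it remains a rough expectation. For compound 4 the estimate is 10000 nM with an expected range from 3000 nM to 30000 nM and a limit of the assay is the likeliest expected outcome.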

Compound 4, half-maximal inhibitory concentration: 5510 nM
Compound 4: middle estimate off by 1.8-fold (0.26 log units), on the high side, and the stated range covers the measured number.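

Within the data shown here, at the double-bonded chain carbon bound to a double-bonded chain carbon, the earlier replacements among compound 1, compound 2 and compound 3 cannot be read, so 5-chloro-2-hydroxyphenyl is the first group here to bring a number within range in this assay. Among these compounds, the same change gives an at least 1.8-fold lower number from compound 3 to compound 4 (0.25 log units; that floor lies within the scatter), an at least 1.8-fold lower number from compound 2 to compound 4 (0.25 log units; that floor lies within the scatter) and an at least 1.8-fold lower number from compound 1 to compound 4 (0.25 log units; that floor lies within the scatter), and each of these is a floor, so the position may matter more than the printed size, but the data show only that the true step is open on one side. Compound 4 is the only member of the set with a measured number, and everything else stands at a limit: the limit of > 10000 nM in this assay, at which 3 of the 4 values shown sit.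

The compounds shown leave open whether the hydroxy group, the chloro group or the two together account for the measured number, since the entering group carries both at once and compound 2 and compound 3 share neither pairing. A phenyl carrying only the hydroxy group, or an amine in place of that hydroxy group, would separate these readings at this position.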